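Chloro scan on the benzyl ring of compound 1

This account rests on a few compounds, and the source may have more. Where it says the series, first, only, none or still open, it means among the compounds named here.

Measured so far:
compound 1, `CC1(C)N=C(N)N=C(N)N1c1ccc(OCc2cccc(S(=O)(=O)F)c2)c(Cl)c1`: 7.72
compound 2, `Cc1cc(S(=O)(=O)F)ccc1COc1ccc(N2C(N)=NC(N)=NC2(C)C)cc1Cl`: 7.38
compound 3, `CC1(C)N=C(N)N=C(N)N1c1ccc(OCc2ccc(Cl)c(S(=O)(=O)F)c2)c(Cl)c1`: 8

The series shares one core and varies the benzyl ring carrying the fluorosulfonyl group. In an assay on isolated protein for inhibition of Dihydrofolate reductase (Mus musculus) (a higher number here means a more potent compound, by a factor of ten per unit of this negative logarithm, a lower number a less potent compound), compound 1 gives 7.72 and stands second of the three numbers. Among the compounds with values here, the nearest value is that of compound 3, and the step of a number 0.28 log units higher from compound 1 to compound 3 (within the scatter) lies within the scatter; compound 2 sits lowest, and its gap to compound 1 is beyond the scatter, though compound 2 differs from compound 1 in more than one place, so no single step is drawn between them.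

Compound 4, `CC1(C)N=C(N)N=C(N)N1c1ccc(OCc2cccc(S(=O)(=O)F)c2Cl)c(Cl)c1`, is not yet measured. It differs from compound 1 by chloro in place of hydrogen on an aromatic carbon. Within the data shown here, the only measured step bearing on it is a number 0.28 log units higher from compound 1 to compound 3 (within the scatter), the same kind of change at another carbon of the same ring, and that step stayed within the scatter. On that basis no step beyond the scatter is expected in this assay, in either direction, and the estimated step of a number 0.12 log units lower from compound 1 to compound 4 (within the scatter) is set close to zero with a wide range, since compound 2 shows that a small group on this ring can also go with a lower value. Compound 4 is therefore expected to give about 7.6 in this assay, between 7 and 8.2.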

Compound 4, logarithm of the reciprocal of the active concentration, log(1/C): 7.49
The estimate for compound 4 lay 0.11 log units above the measured number; the range from low to high includes it.
By their numbers in this assay, from the lowest: compounds 2, 4, 1 and 3 (each within the scatter of the next, the first and the last beyond it).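

In this assay, a chloro on this aromatic carbon, ortho to a fluorosulfonyl group and so ortho to a large group, gives a number 0.23 log units lower from compound 1 to compound 4 (within the scatter), so this carbon carries the added heavy atom without a step beyond the scatter. The same change at another carbon of the ring gives a number 0.28 log units higher from compound 1 to compound 3 (within the scatter), so both chloro steps measured from compound 1 on this ring stay within the scatter, and in these two cases the change does not clearly move the number in either direction. Nothing available bears on why the number holds at this carbon.

The compounds shown carry only a chloro at this carbon, so it remains open whether a larger or differently built group, such as a methoxy, an amine or a carboxylic acid, would also stay within the scatter in this assay. It also remains open whether the chloro step would stay this small if the fluorosulfonyl group were replaced, for example by a sulfonamide, since every compound shown keeps that group.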